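The source may report more compounds than this note shows. Statements on the series, on what has been measured and on what is new or still open speak of the compounds shown alone.

Measured compounds:
compound 1 `COc1cc2c(Oc3ccc(NC(=O)NN4C(=O)CSC4c4c(F)cccc4F)c4ccccc34)ccnc2cc1OCCCN1CCCC1`, 1860 nM;
compound 2 `COc1cc2c(Oc3c(F)cc(NC(=O)NN4C(=O)CCSC4c4c(F)cccc4F)cc3F)ccnc2cc1OCCCN1CCCC1`, 270 nM;
compound 3 `CCN1CCN(CCCOc2cc3nccc(Oc4c(F)cc(NC(=O)NN5C(=O)CSC5c5c(F)cccc5F)cc4F)c3cc2OC)CC1`, 73 nM.

In a functional assay on HT-29 cells (Homo sapiens) for antiproliferative activity, read by MTT assay, with a stated time of 72 h (on this read-out lower numbers stand for stronger inhibition and higher numbers for weaker inhibition), compound 3 gives the lowest number of the three. Compound 2 stands nearest, and that gap lies beyond the scatter; compound 1 lies furthest away, also beyond the scatter. Compound 4 `CCN1CCN(CCCCOc2cc3nccc(Oc4c(F)cc(NC(=O)NN5C(=O)CSC5c5c(F)cccc5F)cc4F)c3cc2OC)CC1` has not yet been tested in this assay. It differs from compound 3 in one place: (4-ethylpiperazin-1-yl)methyl in place of 4-ethylpiperazin-1-yl on a saturated chain carbon, three bonds along the chain from an oxygen on an aromatic ring. Within the data shown here, no pair of measured compounds differs in a comparable way, so no measured step guides the expectation. Going from 3-(4-ethylpiperazin-1-yl)propyl to 4-(4-ethylpiperazin-1-yl)butyl is expected to change the number little, with at most a slight lean toward a weaker result. Compound 4 is therefore estimated at 95 nM, with a range from 35 nM to 260 nM. That estimate means a step of a 1.3-fold higher number from compound 3 to compound 4 (0.11 log units; within the scatter), expected to stay within the scatter.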

Compound 4, half-maximal inhibitory concentration: 830 nM
For compound 4 the middle estimate is 8.7-fold (0.94 log units) below the measured one, outside the stated range (above it).
By their numbers in this assay, from the lowest: compound 3; then compound 2; then compound 4; then compound 1.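

In this assay, replacing 3-(4-ethylpiperazin-1-yl)propyl with 4-(4-ethylpiperazin-1-yl)butyl gives an 11-fold higher number from compound 3 to compound 4 (1.06 log units; beyond the scatter). Among these compounds, this is the first step that can be read at this position, and it shows that the result is highly sensitive to this one-carbon change in the chain. No evidence at hand bears on why the number rises. The compounds shown leave open whether a shorter 2-(4-ethylpiperazin-1-yl)ethyl chain would hold the value of compound 3, and whether the same added carbon would cost as much with a morpholine at the chain end.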